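From 3-methoxyphenyl to 1-benzofuran-4-yl: a solubility estimate

A few compounds are considered here, and "the series" means these few. Any claim that something is new, unique, unknown or untested is made for them only; others in the source may bear on it.

Measured in a physicochemical assay for solubility; on this read-out lower numbers stand for lower solubility and higher numbers for higher solubility:
- compound 1 `CNC(=O)c1cc(C(=O)NC2CC2)cn(Cc2cccc([C@@H](C)O)c2)c1=O`: >= 131 ug/mL (a limit)
- compound 2 `CNC(=O)c1cc(C(=O)NC2CC2)cn(Cc2cccc(OC)c2)c1=O`: 79 ug/mL

In this assay, for the measured compounds named here, compound 2 gives 79 ug/mL, the only actual number so far. The reading for compound 1 is a limit, >= 131 ug/mL, and not a number.

The next compound is compound 3 `CNC(=O)c1cc(C(=O)NC2CC2)cn(Cc2cccc3occc23)c1=O`, which differs from compound 2 as follows: 1-benzofuran-4-yl in place of 3-methoxyphenyl on a saturated chain carbon bound to an aromatic nitrogen. In words, this is 1-benzofuran-4-yl in place of 3-methoxyphenyl on a saturated chain carbon bound to an aromatic nitrogen.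

Going by the values given here, only one measured step is available as a guide, and it is not the same exchange: an at least 1.6-fold lower number from compound 1 to compound 2 (0.21 log units; that floor lies within the scatter), with methoxy in place of 1-hydroxyethyl on an aromatic carbon. It touches the same part of the molecule, but it gives only a floor and so is a weak guide. A small move to a lower number is therefore expected, and it may not exceed the scatter. The expected change is a 1.8-fold lower number from compound 2 to compound 3 (0.24 log units; within the scatter). For compound 3 the estimated value is 45 ug/mL, with an expected range of 15 ug/mL to 110 ug/mL.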

Compound 3, solubility: >= 110 ug/mL
Compound 3 was reported as a limit; the forecaster's own chance of this, stated with the estimate: 5%; middle value at least 2.4-fold (0.38 log units) from the limit.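

In this assay compound 3 gives >= 110 ug/mL, which is a limit and not a number. Replacing 3-methoxyphenyl with 1-benzofuran-4-yl on a saturated chain carbon bound to an aromatic nitrogen gives an at least 1.3-fold higher number from compound 2 to compound 3 (0.14 log units; that floor lies within the scatter), so this position accepts the added five-membered aromatic ring without a lower number, although the floor of the step does not exceed the scatter. For the compounds shown here, the only earlier step concerned a group on an aromatic carbon and pointed to a lower number, whereas this exchange of the whole aromatic group points the other way, and its true size remains unknown.

The readings for compound 1 and compound 3 are both limits, and the step between them cannot be read. From the compounds shown here alone, what number compound 3 would give remains open, as does whether an amine or a carboxylic acid on the 1-benzofuran-4-yl group would change the reading in this assay.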